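The source may report more compounds than this note shows. Statements on the series, on what has been measured and on what is new or still open speak of the compounds shown alone.

Measured compounds in an assay on CHO cells for displacement of a labelled ligand from adenosine receptor A3 (Homo sapiens), read by scintillation counting, with a stated time of 3 h; a lower number here means a stronger inhibitor, a higher number a weaker inhibitor:

- compound 1, `Cn1c(-c2ccc(F)cc2)nc2c(NC3CCCC3)ncnc21`: 1140 nM
- compound 2, `Cn1c(-c2ccccc2)nc2c(NC3CCCCC3)ncnc21`: 2370 nM
- compound 3, `CCn1c(-c2ccccc2)nc2c(NC3CCC3)ncnc21`: 84 nM

Compound 1 stands second highest of the three numbers in this assay. Its nearest neighbour is compound 2, whose number is higher, a gap that lies beyond the usual scatter. Furthest from it is compound 3, whose number is lower, again beyond the scatter. The three compounds differ from one another in more than one place, so no single change can be read out of these numbers on its own.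

Compound 4, `Cc1ccc(-c2nc3c(NC4CCCC4)ncnc3n2C)cc1`, has not been measured in this assay. Relative to compound 1 the change is methyl in place of fluoro on an aromatic carbon, para to a large group. Within the data shown here, nothing among the measured compounds isolates this exchange, so the size of the step is unknown from the data. An exchange of one small uncharged substituent for another at the same place is expected to move the number little, probably not beyond the scatter, with a slight lean toward a lower number.

Compound 4 is therefore estimated at 900 nM, within 350 nM to 2500 nM. The expected step is a 1.3-fold lower number from compound 1 to compound 4 (0.10 log units; within the scatter).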

Compound 4, inhibition constant: 480 nM
Compound 4: middle estimate off by 1.9-fold (0.27 log units), on the high side; the range from low to high includes it.
By their numbers in this assay, from the lowest: compound 3; then compound 4; then compound 1; then compound 2.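

In this assay, among these compounds, the exchange of 4-fluorophenyl for 4-methylphenyl gives a 2.4-fold lower number from compound 1 to compound 4 (0.38 log units; beyond the scatter), the only step so far that can be read from a change in one place. This position on the six-membered aromatic ring, para to a large group, therefore responds measurably: one heavy atom replaces another, with no change in ring, hydrogen-bond donor or acceptor count, or net charge, and the modest step still lies beyond the scatter. Nothing measured here accounts for the direction or size of this step.

Chloro, methoxy, trifluoromethyl or an unsubstituted hydrogen at this place would show whether the step reflects a wider trend or is specific to this pair, and a longer chain such as ethyl or propyl would show how much further substitution is tolerated. Steps involving compound 2 and compound 3 cannot be read, since each differs from the others in more than one place, so it also remains open whether the same exchange would give a similar step with a different amine ring or N-alkyl group.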